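Swapping the phenyl of compound 1 for a dithiocarbamate ester

The source may report more compounds than this note shows. Statements on the series, on what has been measured and on what is new or still open speak of the compounds shown alone.

Compound 1 `CN(C)C(=S)SC(=S)N1CCN(c2ccccc2)CC1` is the reference point of this small set. In an ADME assay on HeLa cells (Homo sapiens) for cytotoxicity, read by MTT assay, with a stated time of 24 h (on this read-out lower numbers stand for stronger inhibition and higher numbers for weaker inhibition), compound 1 gives 1610000 nM, the lowest of the three numbers measured. Compound 3 `CN(C)C(=S)SC(=S)N1CCN(c2cccc(C(F)(F)F)c2)CC1` gives 2760000 nM, and the step of a 1.7-fold higher number from compound 1 to compound 3 (0.23 log units; within the scatter) stays within the scatter. Compound 2 `COc1ccccc1N1CCN(C(=S)SC(=S)N(C)C)CC1` gives 4330000 nM, and the step of a 2.7-fold higher number from compound 1 to compound 2 (0.43 log units; beyond the scatter) is modest but beyond the scatter.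

Compound 4 `CCSC(=S)N1CCN(C(=S)SC(=S)N(C)C)CC1` is not yet measured in this assay. It differs from compound 1 in this way: a group of 5 heavy atoms (3 carbon, 2 sulfur; no ring) in place of a group of 6 heavy atoms (6 carbon; one six-membered aromatic ring of carbon only), on an amine nitrogen in a ring. Both measured steps changed only a substituent on the phenyl while keeping the ring; neither removes the ring, so they bear on the new step only loosely. They do show that changes at this end of the shared core moved the number by small amounts only. The expectation is therefore a step of a 1.2-fold higher number from compound 1 to compound 4 (0.09 log units; within the scatter) from compound 1 to compound 4 that stays close to or within the scatter, without a firm direction. Compound 4 is expected to give about 2000000 nM, with a range from 700000 nM to 6000000 nM.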

Compound 4, half-maximal inhibitory concentration: 4480000 nM
For compound 4 the middle estimate is 2.2-fold (0.35 log units) below the measured one; measured number inside the range.
By their numbers in this assay, from the lowest: compounds 1, 3, 2 and 4 (each within the scatter of the next, the first and the last beyond it).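

In this assay the change is read as a step of a 2.8-fold higher number from compound 1 to compound 4 (0.44 log units; beyond the scatter), so the phenyl on this amine nitrogen can give way to an open group with no ring at all while the number moves only modestly, though beyond the scatter. Among these compounds, the earlier compounds kept the aromatic ring and changed only its substituents, so compound 4 is the first here to show what happens at this position when that ring is gone. Nothing at hand says what lies behind this step.

The compounds shown leave open whether a saturated ring such as cyclohexyl, or a plain alkyl chain without sulfur, would give a number closer to that of compound 1 or to that of compound 4. They also leave open how an amine or a carboxylic acid at this position would read.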